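Swapping a dihydroxyphenyl for a dimethylaminophenyl arm

The source may hold more compounds than are shown below. What is called first, only, known or untested is meant among the compounds shown, and "the series" means these compounds.

Measured so far:
compound 1 `CCc1ccc(N2C(=O)/C(=C/c3ccc(N(C)C)cc3)N(C)C2=S)cc1` — 4390 nM
compound 2 `CN1C(=S)N(c2ccc3c(c2)CCC3)C(=O)/C1=C/c1ccc(O)cc1O` — 6580 nM
compound 3 `CN1C(=S)N(c2ccc3c(c2)CCC3)C(=O)/C1=C/c1cccc(O)c1O` — 6630 nM

In an assay for inhibition of NADPH oxidase 1 (Homo sapiens), read by chemiluminescence (a lower number here means a stronger inhibitor, a higher number a weaker inhibitor), compound 3 gives 6630 nM, the highest of the three numbers, though its neighbours lie close: compound 2 is a 1.0-fold higher number from compound 2 to compound 3 (0.00 log units; within the scatter) away, and compound 1 gives 4390 nM, which is also within the scatter of compound 3. Among the compounds with values here, the one measured step, a 1.0-fold higher number from compound 2 to compound 3 (0.00 log units; within the scatter), moves a hydroxyl around the same ring and changes nothing beyond the scatter.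

Compound 4 `CN1C(=S)N(c2ccc3c(c2)CCC3)C(=O)/C1=C/c1ccc(N(C)C)cc1` differs from compound 3 by 4-(dimethylamino)phenyl in place of 2,3-dihydroxyphenyl on a double-bonded chain carbon bound to a double-bonded ring carbon. Within the data shown here, no measured step covers this exchange directly. Compound 1 carries the same 4-(dimethylamino)phenyl on a core that differs elsewhere, and its value against compound 3 shows only a gap within the scatter. The step from compound 3 to compound 4 in this assay is therefore expected to be small, roughly a 1.5-fold lower number from compound 3 to compound 4 (0.17 log units; within the scatter), leaning toward the number of compound 1. Compound 4 is estimated at 4500 nM, with a range from 1500 nM to 13000 nM.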

Compound 4, inhibition constant: 8040 nM
For compound 4 the middle estimate is 1.8-fold (0.25 log units) below the measured one; the range from low to high includes it.
By their numbers in this assay, from the lowest: compounds 1, 2, 3 and 4 (each within the scatter of the next).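

In this assay, 4-(dimethylamino)phenyl, with 0 hydrogen-bond donors, takes the place of arms that carry hydroxyl groups on a double-bonded chain carbon bound to a double-bonded ring carbon, giving a 1.2-fold higher number from compound 3 to compound 4 (0.08 log units; within the scatter) and a 1.2-fold higher number from compound 2 to compound 4 (0.09 log units; within the scatter), so on this shared core the number stays within the scatter with or without those hydroxyl groups. With that arm held fixed, the exchange on the amide-type nitrogen in a ring, 2,3-dihydro-1H-inden-5-yl in place of 4-ethylphenyl, gives a 1.8-fold higher number from compound 1 to compound 4 (0.26 log units; within the scatter), which also stays within the scatter. Nothing at hand explains why these numbers stay so close.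

As far as these compounds go, whether any group at this position can move the number beyond the scatter remains open. A carboxylic acid or a primary amine on the phenyl ring of this arm, for example, could still give a different result.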